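The source may report more compounds than this note shows. Statements on the series, on what has been measured and on what is new or still open speak of the compounds shown alone.

Compound 1 `Cc1cc(=O)oc2cc(SCc3ccccn3)ccc12`: > 35200 nM
Compound 2 `Cc1cc(=O)oc2cc(SCc3ccncc3)ccc12`: > 35200 nM
Compound 3 `COC(=O)c1cccc(CSc2ccc3c(C)cc(=O)oc3c2)c1`: 14100 nM

All three compounds share one core and differ only in the group carried on the saturated chain carbon bound to the sulfur. In a functional assay on DU-145 cells (Homo sapiens) for antiproliferative activity, read by sulforhodamine B assay, with a stated time of 72 h (on this read-out lower numbers stand for stronger inhibition of growth and higher numbers for weaker inhibition of growth), compound 1 gives > 35200 nM, which is a limit of the assay and not a number. Compound 2 likewise gives > 35200 nM, also a limit. Two of the three values therefore sit at the limit of > 35200 nM in this assay, at which 2 of the 3 values shown sit. Among the measured compounds shown here, compound 3 gives 14100 nM, the only number among the three. For the measured compounds named here, the one measured step, a step that the two limits leave unreadable from compound 1 to compound 2, cannot be sized, because both of its ends are limits.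

Compound 4 `Cc1cccc(CSc2ccc3c(C)cc(=O)oc3c2)c1` differs from compound 3 in one place: methyl in place of methoxycarbonyl on an aromatic carbon. Going by the values given here, no measured step involves such a change, and the only measured step gives no readable size, so there is nothing to point in either direction. The expectation is therefore a step within the scatter, a 1.1-fold higher number from compound 3 to compound 4 (0.03 log units; within the scatter), starting from compound 3 and its value 14100 nM. Compound 4 is estimated at 15000 nM, within a range from 5000 nM to 35200 nM.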

Compound 4, concentration for 50% growth inhibition: > 33700 nM
Compound 4 gave a limit, no number (the forecaster's own chance of this, stated with the estimate: 35%); middle value at least 2.2-fold (0.35 log units) from the limit.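

In this assay compound 4 gives > 33700 nM, which is a limit of the assay and not a number. Methyl in place of methoxycarbonyl on this aromatic carbon produces the first step of readable size in the series, an at least 2.3-fold higher number from compound 3 to compound 4 (0.37 log units; beyond the scatter), so the group at this place does affect growth inhibition, which the earlier compounds could not show. The steps from compound 1 and from compound 2 to compound 4 cannot be read, as both ends of each are limits.

The compounds shown leave open which part of the methoxycarbonyl group matters, and a carboxylic acid or a primary amide at the same place would bear on that. From the compounds shown here alone, how far compound 4 lies past its limit also remains unknown, so the full size of this step stays open.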